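Moving a Chlorine Around a Phenyl Ring on a Shared Core

This account rests on a few compounds, and the source may have more. Where it says the series, first, only, none or still open, it means among the compounds named here.

Of the compounds shown here, three have been tested in an assay on isolated protein for inhibition of DNA topoisomerase 1 (Homo sapiens), with a stated time of 30 min, tested at 100 uM; a higher number here means a stronger effect of the compound at the concentration tested, a lower number a weaker effect. Compound 1 `Oc1cccc(-c2cc(-c3cccnc3)nc(-c3cccc(Cl)c3)c2)c1` gives 27.6%. Compound 3 `Oc1ccc(-c2cc(-c3cccc(Cl)c3)nc(-c3ccccn3)c2)cc1` gives 59.4%, and compound 2 `Oc1ccc(-c2cc(-c3ccccn3)nc(-c3ccccc3Cl)c2)cc1` gives 5.2%. Compound 2 differs from compound 3 by a single change, (2-chlorophenyl in place of 3-chlorophenyl on an aromatic carbon), and the result was a drop: a number 54.2 percentage points lower from compound 3 to compound 2 (beyond the scatter). How the core of compound 1 differs from that of compound 3 is not broken down here.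

Compound 4 `Oc1cccc(-c2cc(-c3cccnc3)nc(-c3ccccc3Cl)c2)c1` has not yet been measured in this assay. It is related to compound 1 by 2-chlorophenyl in place of 3-chlorophenyl on an aromatic carbon. Among the measured compounds shown here, this is the same kind of change as the one from compound 3 to compound 2, but not the same, since the surroundings differ: in compound 1 the place is meta to a 3-hydroxyphenyl group and meta to a pyridin-3-yl group, whereas in compound 3 it is meta to a 4-hydroxyphenyl group and meta to a pyridin-2-yl group.

If the change behaves as it did before, compound 4 is expected to lose activity, with a step of roughly a number 21.6 percentage points lower from compound 1 to compound 4 (beyond the scatter), because compound 1 starts from 27.6% and cannot fall as far as the earlier drop. Compound 4 is therefore estimated at 6%, plausibly between 0% and 22%.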

Compound 4, a percentage reported as inhibition, at one concentration (the size of the read-out at that concentration, not a potency): 0%
Beside the measured number, compound 4's estimate is 6 percentage points above it; the measured number falls inside the stated range.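

In this assay the change from 3-chlorophenyl to 2-chlorophenyl lowers the read-out on a second core (a number 27.6 percentage points lower from compound 1 to compound 4 (beyond the scatter)), so on these two cores its direction carries over, but its size does not: the same change on two cores in this assay, a number 54.2 percentage points lower (beyond the scatter) from compound 3 to compound 2 and a number 27.6 percentage points lower (beyond the scatter) from compound 1 to compound 4, 26.6 percentage points apart, beyond the scatter of two such steps. Compound 4 gives 0%, so on this core the read-out has no room left to fall, and the smaller step cannot be taken as a milder effect of the change. Since the two cores differ in both the hydroxyphenyl and the pyridinyl group, these pairs do not show which of those groups, if either, matters for the size of the step, nor how the change would behave on any other core.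

The compounds shown leave open what would happen if the chlorine gave way to another group, such as a methoxy group or an amine. They also leave open whether a carboxylic acid could stand in for the hydroxyl group on the shared core.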